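Adding a Third Methoxy Group to the Lactone Series

The source may hold more compounds than are shown below. What is called first, only, known or untested is meant among the compounds shown, and "the series" means these compounds.

Compound 1, `COc1ccc(/C=C/C2CC=CC(=O)O2)cc1`, gives 28.3 uM
Compound 2, `COc1ccc(/C=C/C2CC=CC(=O)O2)c(OC)c1`, gives 6 uM
Compound 3, `COc1ccc(/C=C/C2CC=CC(=O)O2)cc1OC`, gives 14.6 uM

These three compounds share one core and differ only in the methoxy groups on the aromatic ring. All were tested in a functional assay on NCI-H460 cells (Homo sapiens) for inhibition, read by sulforhodamine B assay, with a stated time of 48 h; on this read-out higher numbers stand for weaker inhibition of growth and lower numbers for stronger inhibition of growth. Compound 3 holds the second highest of the three numbers: its nearest neighbour is compound 1, whose value lies within the scatter of its own, and its furthest is compound 2, which lies beyond the scatter on the lower side.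

Compound 4, `COc1cc(OC)c(OC)cc1/C=C/C1CC=CC(=O)O1`, is not yet measured. It differs from compound 3 in one place: methoxy in place of hydrogen on an aromatic carbon.

Within the data shown here, two measured steps bear on this change, since both add a methoxy group to the aromatic ring of compound 1. The step of a 4.7-fold lower number from compound 1 to compound 2 (0.67 log units; beyond the scatter) was clearly beyond the scatter, whereas the step of a 1.9-fold lower number from compound 1 to compound 3 (0.29 log units; within the scatter) stayed within it. The new methoxy group of compound 4 takes the same place on the ring that distinguishes compound 2 from compound 1, so a step toward a lower number, of modest size, is expected, a 2.9-fold lower number from compound 3 to compound 4 (0.47 log units; beyond the scatter).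

On this basis compound 4 is estimated at 5 uM in this assay, with a likely range from 1.5 uM to 15 uM.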

Compound 4, concentration for growth inhibition (reported as GI): 9.8 uM
Beside the measured number, compound 4's estimate is 2.0-fold (0.29 log units) below it; low and high end bracket the measured number.
By their numbers in this assay, from the lowest: compounds 2, 4, 3 and 1 (each within the scatter of the next, the first and the last beyond it).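

On compound 3, the methoxy group that enters ortho to the group of 9 heavy atoms gives only a 1.5-fold lower number from compound 3 to compound 4 (0.17 log units; within the scatter), so the same change counts for less here than it did on the one-methoxy core, and the size of its step depends on what the ring already carries: the same change on two cores in this assay, a 4.7-fold lower number (0.67 log units; beyond the scatter) from compound 1 to compound 2 and a 1.5-fold lower number (0.17 log units; within the scatter) from compound 3 to compound 4, 3.2-fold (0.50 log units) apart, beyond the scatter of two such steps

The other route to the three-methoxy ring, with a 1.6-fold higher number from compound 2 to compound 4 (0.21 log units; within the scatter), shows the same dependence, since adding a methoxy group at this second place gives no clear shift on either core, yet the two steps still lie apart: the same change on two cores in this assay, a 1.9-fold lower number (0.29 log units; within the scatter) from compound 1 to compound 3 and a 1.6-fold higher number (0.21 log units; within the scatter) from compound 2 to compound 4, 3.2-fold (0.50 log units) apart, beyond the scatter of two such steps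

Compound 4 therefore stands within the scatter of both two-methoxy compounds, compound 2 and compound 3, so on these numbers a third methoxy group brings no clear separation from either of them.

Open, on these data alone, is whether a hydroxyl group, a chlorine atom or a longer ethoxy chain in the same place, ortho to the group of 9 heavy atoms, would behave as methoxy does on these cores. Also open is why the step shrinks on the richer ring, as these four numbers give its size and nothing about its origin.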